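Chloro in Place of Aminopentylamino on Two Cores

The source may report more compounds than this note shows. Statements on the series, on what has been measured and on what is new or still open speak of the compounds shown alone.

Compound 1 `CC(C)Cc1nn(C)c(=O)c2c(SCCCO)n(Cc3cc(NCCCCCN)nc4ccccc34)cc12` gives 24 nM in an assay on Raji cells for inhibition of Monocarboxylate transporter 1 (Homo sapiens), read by MTT assay, with a stated time of 96 h; on this read-out lower numbers stand for an effect already at smaller amounts and higher numbers for an effect only at larger amounts of compound. Compound 3 `CC(C)Cc1nn(C)c(=O)c2c(SCCCO)n(Cc3cc(Cl)nc4ccccc34)cc12` carries chloro in place of (5-aminopentyl)amino on an aromatic carbon, and in this assay compound 3 gives 60 nM, so that a 2.5-fold higher number from compound 1 to compound 3 (0.40 log units; beyond the scatter). Compound 2 `CC(C)Cc1nn(C)c(=O)c2c(SCCCO)n(Cc3ccnc(NCCCCCN)c3)cc12` rests on a different core; how the two cores differ is not broken down here. In this assay compound 2 gives 520 nM, the highest of the three numbers. Compound 4 `CC(C)Cc1nn(C)c(=O)c2c(SCCCO)n(Cc3ccnc(Cl)c3)cc12` arises from compound 2 through (chloro in place of (5-aminopentyl)amino on an aromatic carbon), the same kind of change as that between compound 1 and compound 3, though there the place lies in a ring that is part of a fused or bridged system of two rings, meta to a fused ring and para to a fused ring. A step of similar size is expected, a 2.5-fold higher number from compound 2 to compound 4 (0.40 log units; beyond the scatter), because of a 2.5-fold higher number from compound 1 to compound 3 (0.40 log units; beyond the scatter). Compound 4 is therefore estimated at 1300 nM in this assay, expected to fall between 500 nM and 3500 nM.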

Compound 4, half-maximal effective concentration: 1000 nM
For compound 4 the middle estimate is 1.3-fold (0.11 log units) above the measured one; the measured number falls inside the stated range.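

In this assay chloro in place of (5-aminopentyl)amino, carried to the core of compound 2, gives a 1.9-fold higher number from compound 2 to compound 4 (0.28 log units; within the scatter) and so does not clearly separate the two compounds, although the same change on the core of compound 1 lay beyond the scatter. The two steps still agree in size: the same change on two cores in this assay, a 2.5-fold higher number (0.40 log units; beyond the scatter) from compound 1 to compound 3 and a 1.9-fold higher number (0.28 log units; within the scatter) from compound 2 to compound 4, 1.3-fold (0.11 log units) apart, within the scatter of two such steps. Among these compounds, this shows that the change carried across these two cores with a step of similar size, but it rests on only two pairs and does not show why the two cores stand so far apart.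

The compounds shown leave open whether a shorter or longer chain ending in an amine would give the same step on both cores. They also leave open how a carboxylic acid at the end of the chain would behave.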